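The source may hold more compounds than are shown below. What is called first, only, known or untested is meant among the compounds shown, and "the series" means these compounds.

Compound 1 `Cn1cncc1C(OCc1ccc(C#N)cc1-c1cccc2ccccc12)c1ccc(C#N)nc1` is the reference point of this set in an assay on isolated protein (Bos taurus) for inhibition of geranylgeranyl transferase type-1 subunit beta (Homo sapiens); on this read-out higher numbers stand for weaker inhibition and lower numbers for stronger inhibition. For compound 1 the read-out is a limit of the assay, > 10 nM, so no number stands behind it. In this assay compound 2 `Cn1cncc1C(OCc1ccc(C#N)c(-c2ccc3ccccc3c2)n1)c1ccc(C#N)cc1` gives 2600 nM. Compound 3 `Cn1cncc1C(OCc1ccc(C#N)nc1-c1ccc(OC(F)(F)F)cc1)c1ccc(C#N)cc1` gives 1200 nM in this assay. No step between measured compounds is shown, and the limit for compound 1 the limit of > 10 nM in this assay, at which 1 of the 3 values shown sits, leaves its standing open.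

Compound 4 `Cn1cncc1C(OCc1ccc(C#N)cc1-c1cc(F)cc(F)c1)c1ccc(C#N)nc1` differs from compound 1 by 3,5-difluorophenyl in place of naphthalen-1-yl on an aromatic carbon. Going by the values given here, with compound 2 at 2600 nM and compound 3 at 1200 nM as the only numbers available, compound 4 is expected to land in this assay near 1500 nM, within 300 nM to 8000 nM. The step from compound 1 to compound 4 is estimated as a step that the limit leaves unreadable from compound 1 to compound 4, its direction left open by the limit.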

Compound 4, half-maximal inhibitory concentration: > 10 nM
Compound 4: no number, only a limit; the forecaster's own chance of this, stated with the estimate: 20%; the middle value does not contradict the limit.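

In this assay compound 1 and compound 4 both stand only as limits, so no step can be read between them: the limit of > 10 nM in this assay, at which 2 of the 4 values shown sit.

Going by these compounds, whether 3,5-difluorophenyl or naphthalen-1-yl gives the stronger inhibition on this core stays open.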